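The source may report more compounds than this note shows. Statements on the series, on what has been measured and on what is new or still open speak of the compounds shown alone.

Compound 2 `CC(C)C(CC1NC(=O)NC1=O)c1ccc(-c2ccc3cccc(F)c3c2)[nH]c1=O` stands lowest of the two numbers in an ADME assay on microsomes from liver (Rattus norvegicus) for metabolic stability; a higher number here means that the compound lasts longer, a lower number that the compound disappears faster; compound 2 gives 0.35 h, while compound 1 `CC(C)C(/C=C1\NC(=O)NC1=O)c1ccc(-c2ccc3cccc(F)c3c2)[nH]c1=O` gives 1.46 h. Among the measured compounds shown here, the single measured step, a 4.2-fold lower number from compound 1 to compound 2 (0.62 log units; beyond the scatter), bears directly on the next change. Compound 3 `CC(C)C(/C=C1/C(=O)NC(=O)N1C)c1ccc(-c2ccc3cccc(F)c3c2)[nH]c1=O` differs from compound 2 by a group of 9 heavy atoms (5 carbon, 2 nitrogen, 2 oxygen; one five-membered non-aromatic ring with 2 hetero atoms) in place of a group of 8 heavy atoms (4 carbon, 2 nitrogen, 2 oxygen; one five-membered non-aromatic ring with 2 hetero atoms), on a saturated chain carbon bound to an aromatic carbon and a saturated chain carbon. This change runs largely in the direction opposite to that step, adding one double bond outside aromatic rings and removing one hydrogen-bond donor, so a step upward beyond the scatter is expected. Compound 3 is expected to give 1.2 h, within 0.4 h to 3.5 h. The expected step is a 3.4-fold higher number from compound 2 to compound 3 (0.54 log units; beyond the scatter), roughly the reverse of a 4.2-fold lower number from compound 1 to compound 2 (0.62 log units; beyond the scatter).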

Compound 3, half-life in the Rattus norvegicus assay: 1.08 h
Compound 3: the middle estimate sits 1.1-fold (0.05 log units) above what was measured, and the stated range covers the measured number.
By their numbers in the Rattus norvegicus assay, from the lowest: compound 2; then compounds 3 and 1 (each within the scatter of the next).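

In the Rattus norvegicus assay, methyl in place of hydrogen on an amide-type nitrogen in a ring gives a 1.4-fold lower number from compound 1 to compound 3 (0.13 log units; within the scatter), so this methyl is tolerated on the unsaturated group. Against the saturated (2,5-dioxoimidazolidin-4-yl)methyl, the group of compound 3 gives a 3.1-fold higher number from compound 2 to compound 3 (0.49 log units; beyond the scatter), which recovers what the saturated group lost. In a physicochemical assay for solubility, in phosphate buffer, measured as kinetic solubility (on this read-out higher numbers stand for higher solubility and lower numbers for lower solubility), compound 2 gives 12300 nM and compound 3 gives 34800 nM, so both read-outs move upward on this change.

Open, as far as these compounds go, is how much of this change rests on the extra double bond and how much on the methyl. Also open, from the compounds shown here alone, is whether an ethyl or a chain ending in a carboxylic acid on that nitrogen would hold both numbers.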